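Freeing the phenol: from compound 2 to compound 4

A few compounds are considered here, and "the series" means these few. Any claim that something is new, unique, unknown or untested is made for them only; others in the source may bear on it.

Three members of the series share one core and a triazole-linked aryl group, and all three stop at the same place. Compound 1 `C=C1C[C@]23C[C@@]1(O)CC[C@H]2c1ccc(OS(=O)(=O)c2ccc(C)cc2)c(C)c1[C@@H]3Cn1cc(-c2ccc(Br)cc2)nn1` carries bromo on an aromatic carbon; compound 2 `C=C1C[C@]23C[C@@]1(O)CC[C@H]2c1ccc(OS(=O)(=O)c2ccc(C)cc2)c(C)c1[C@@H]3Cn1cc(-c2ccc(OC)cc2)nn1` has methoxy in place of bromo on that aromatic carbon. In a functional assay on SW480 cells (Homo sapiens) for cytotoxicity, read by MTT assay, with a stated time of 4 days (a lower number here means a stronger inhibitor, a higher number a weaker inhibitor), compound 1 gives only > 20000 nM, which is a limit of the assay and not a number. Compound 2 likewise gives only the limit > 20000 nM in this assay. The step that the two limits leave unreadable from compound 1 to compound 2 is therefore unreadable. Within the data shown here, compound 3 `COc1ccc(-c2cn(C[C@H]3c4c(ccc(O)c4C)[C@@H]4CC[C@@]5(C)C[C@]43CC5=O)nn2)cc1`, which has a free hydroxy on its aromatic ring and a differing core, also reaches only the limit > 20000 nM in this assay; no step between compound 2 and compound 3 is computed, and both values show only a limit. Compound 2 thus stands at the limit together with the other two values (the limit of > 20000 nM in this assay, at which 3 of the 3 values shown sit).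

Compound 4 `C=C1C[C@]23C[C@@]1(O)CC[C@H]2c1ccc(O)c(C)c1[C@@H]3Cn1cc(-c2ccc(OC)cc2)nn1` differs from compound 2 by hydrogen in place of (4-methylphenyl)sulfonyl on an oxygen on an aromatic ring. Among the measured compounds shown here, no measured step bears directly on this change; the one step in hand, a step that the two limits leave unreadable from compound 1 to compound 2, could not be sized, and compound 3, which shares the free hydroxy, also sits at the limit. The expected step in this assay is a step that the limit leaves unreadable from compound 2 to compound 4, with a further limit the likeliest report. Compound 4 is estimated at 25000 nM, between 8000 nM and 80000 nM.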

Compound 4, half-maximal inhibitory concentration: > 20000 nM
Compound 4 ended at the assay's limit (the forecaster's own chance of this, stated with the estimate: 70%); the middle value does not contradict the limit.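

In this assay compound 4 gives > 20000 nM, a limit and not a number. Among these compounds, compound 2 also stands at a limit, so no step between compound 2 and compound 4 can be read. The compounds shown leave open what size any of these changes has, since none gives a value short of the limit: the limit of > 20000 nM in this assay, at which 4 of the 4 values shown sit.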